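Adding a Carbonyl to Compound 2

The source may hold more compounds than are shown below. What is called first, only, known or untested is meant among the compounds shown, and "the series" means these compounds.

Of the compounds shown here, three with a shared core have been measured in an ADME assay on microsomes from liver (Homo sapiens) for metabolic stability, with a stated time of 10 min, tested at 0.5 uM; a higher number here means that more of the compound is left, a lower number that less of the compound is left. Compound 1 `C[C@@H](C(=O)NC1CCCCC1)[C@H]1CC[C@@H](c2ccnc3ccc(F)cc32)CC1`, with a cyclohexylcarbamoyl group, gives < 1%, which is a limit and not a number. Among the measured compounds shown here, compound 2 `C[C@@H](CNc1ccc(Cl)cc1)[C@H]1CC[C@@H](c2ccnc3ccc(F)cc32)CC1` gives 80%, the highest number so far, and compound 3 `C[C@@H](NCc1ccc(Cl)cc1)[C@H]1CC[C@@H](c2ccnc3ccc(F)cc32)CC1` gives 34%.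

Compound 4 `C[C@@H](CNC(=O)c1ccc(Cl)cc1)[C@H]1CC[C@@H](c2ccnc3ccc(F)cc32)CC1` keeps the chain of compound 2 but has (4-chlorophenyl)carbonyl in place of 4-chlorophenyl on an amine nitrogen. For the measured compounds named here, no measured step makes exactly this change, so the evidence is indirect. Changes in this part of the molecule have mattered: the data show a number 46 percentage points lower from compound 2 to compound 3 (beyond the scatter), and also a number at least 79 percentage points higher from compound 1 to compound 2 (beyond the scatter). That second step matters most here, since the cyclohexylcarbamoyl group of compound 1 also holds a carbonyl. Compound 1 differs in other ways, however, so only part of that drop is expected to carry over.

A large fall is expected in this assay, estimated as a number 40 percentage points lower from compound 2 to compound 4 (beyond the scatter). For compound 4 the estimated value is 40%, with an expected range from 10% to 75%.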

Compound 4, percent of the compound remaining: 56%
Beside the measured number, compound 4's estimate is 16 percentage points below it; low and high end bracket the measured number.
By their numbers in this assay, from the lowest: compound 3; then compound 4; then compound 2. At a limit, below all of these: compound 1.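

In this assay, swapping 4-chlorophenyl for (4-chlorophenyl)carbonyl on the amine nitrogen gives a number 24 percentage points lower from compound 2 to compound 4 (beyond the scatter). This is the first step shown that keeps the chain of compound 2 and changes only what sits on that nitrogen, so it isolates the effect of adding a carbonyl there: a real loss, but a modest one. Compound 1 also holds a carbonyl, but it differs from compound 4 in more than one place, and the value of compound 1 is a limit and not a number: the limit of < 1% in this assay, at which 1 of the 4 values shown sits.

Still open, from the compounds shown here alone, is how other groups on this amine nitrogen would compare, such as a sulfonyl group or a urea in place of the carbonyl. It is also unknown whether the step would keep its size with a methoxy group in place of the chlorine, or with a longer chain.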